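A few compounds are considered here, and "the series" means these few. Any claim that something is new, unique, unknown or untested is made for them only; others in the source may bear on it.

Measured so far in a functional assay on the whole organism for positive allosteric modulation, with Mus musculus as the target; a higher number here means that more compound is needed for the effect, a lower number that less compound is needed:
- Compound 1 `CCC(=O)N(c1ccc(OC)cc1)C1CCCCC1N(C)C`: > 50 mg/kg (a limit of the assay, not a number)
- Compound 2 `CCCN(CCC)C1CCCC1N(C(=O)CC)c1ccc(Cl)c(Cl)c1`: 2 mg/kg

For the measured compounds named here, compound 2 holds the only true number in this assay, at 2 mg/kg. Compound 3 `CCC(=O)N(c1ccc(Cl)c(Cl)c1)C1CCCC1N(C)CCCN(C)C` has not yet been measured. It differs from compound 2 in one place: (3-(dimethylamino)propyl)(methyl)amino in place of dipropylamino on a saturated ring carbon. Put simply, (3-(dimethylamino)propyl)(methyl)amino stands in place of dipropylamino on a saturated ring carbon. Going by the values given here, no measured pair of compounds shows what a change of this kind does, so any forecast is uncertain. A single number leaves little to go on, but a swap in this side chain is expected to raise the dose needed by more than the usual scatter. The expected change is a 6.0-fold higher number from compound 2 to compound 3 (0.78 log units; beyond the scatter). For compound 3 the estimated dose is 12 mg/kg, with an expected range of 3 mg/kg to 50 mg/kg.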

Compound 3, dose for half-maximal effect: 4 mg/kg
Compound 3: middle estimate off by 3.0-fold (0.48 log units), on the high side; low and high end bracket the measured number.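

For the compounds shown here, this is the first step measured at this saturated ring carbon of a five-membered non-aromatic ring. In this assay putting (3-(dimethylamino)propyl)(methyl)amino in place of dipropylamino gives a 2.0-fold higher number from compound 2 to compound 3 (0.30 log units; within the scatter) and so leaves the two compounds level within the usual scatter, which means that, for this pair, the position takes the new side chain, with its additional nitrogen, without a change that can be read. Nothing measured here explains why the two side chains read alike.

As far as these compounds go, whether a carboxylic acid at the end of the chain, or a shorter chain ending in a dimethylamino group, would also keep the dose needed in this range stays open. From the compounds shown here alone, it is also open whether the same swap would read alike with other groups elsewhere on the shared core.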